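A few compounds are considered here, and "the series" means these few. Any claim that something is new, unique, unknown or untested is made for them only; others in the source may bear on it.

Compound 1, with the structure `CC1=C(C(=O)Nc2ccc(F)cc2)C(c2ccc([N+](=O)[O-])cc2)N=C(SCc2ccccc2Cl)N1`, and compound 2, with the structure `CC1=C(C(=O)Nc2ccc(F)cc2)C(c2ccc([N+](=O)[O-])cc2)N=C(SCc2cccc(Cl)c2)N1`, share one core and differ only in one place. In a functional assay on the whole organism (artery, strain albino) with Rattus norvegicus as the target, with a stated time of 120 min, at a dose of 10 mg/kg by the oral route (on this read-out lower numbers stand for less inhibition and higher numbers for more inhibition at the one dose given (going by the name of the read-out)), compound 1 gives 8.8%, and in this assay compound 2 gives 9.8%. The change between them is 3-chlorophenyl in place of 2-chlorophenyl on a saturated chain carbon bound to a sulfur, and it made the step of a number 1 percentage points higher from compound 1 to compound 2 (within the scatter). Compound 3, with the structure `CC1=C(C(=O)Nc2ccc(Br)cc2)C(c2ccc(Cl)cc2Cl)N=C(SCc2ccccc2Cl)N1`, is built on a different core; the difference between its core and the core of compound 1 is not broken down here. In this assay compound 3 gives 16%. Compound 4, with the structure `CC1=C(C(=O)Nc2ccc(Br)cc2)C(c2ccc(Cl)cc2Cl)N=C(SCc2cccc(Cl)c2)N1`, is not yet measured. It differs from compound 3 by 3-chlorophenyl in place of 2-chlorophenyl on a saturated chain carbon bound to a sulfur, which is the same change already seen between compound 1 and compound 2, made at the same place. Among the compounds with values here, since that earlier change gave only the step of a number 1 percentage points higher from compound 1 to compound 2 (within the scatter), the step from compound 3 to compound 4 is expected to be about a number 1 percentage points higher from compound 3 to compound 4 (within the scatter). The value of compound 4 in this assay is therefore estimated at 17%, most likely between 6% and 30%.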

Compound 4, a percentage reported as inhibition, in the whole organism at one dose (the size of the read-out at that dose, not a potency): 8.8%
For compound 4 the middle estimate is 8.2 percentage points above the measured one; low and high end bracket the measured number.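

In this assay, exchanging 2-chlorobenzyl for 3-chlorobenzyl on the sulfur gives a number 7.2 percentage points lower from compound 3 to compound 4 (within the scatter), and set beside the same change on the core of compound 1, this step does not differ from the earlier one by more than repeated measurements would: the same change on two cores in this assay, a number 1 percentage points higher (within the scatter) from compound 1 to compound 2 and a number 7.2 percentage points lower (within the scatter) from compound 3 to compound 4, 8.2 percentage points apart, within the scatter of two such steps On these two cores, then, the change has no effect that can be told apart from the scatter, and nothing suggests that the core alters its outcome. This does not prove that the change carries over unchanged to other cores, as two pairs are few and a small real effect could stay hidden in the scatter.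

The compounds shown leave open what happens when the benzyl group on the sulfur carries a methoxy group, an amine or a carboxylic acid in place of chlorine, or gives way to a longer chain. They also leave open how these compounds compare at other doses, as each number comes from one dose.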